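The compounds below may be only part of what the source reports. "The series", "measured", "known", "first", "only" and "open" are said of these compounds alone.

The series keeps one core throughout, carried by compound 1 `CCOC(=O)CCCCCOc1cccc(CN(C(=O)c2ccc(-c3cccnc3)cc2)C(C)C)c1` and compound 2 `CCOC(=O)CCCCCOc1cccc(CN(C(=O)c2ccc(-c3cccc(OCC)c3)cc2)C(C)C)c1`. In an ADME assay on BJ cells (Homo sapiens) for cytotoxicity, read by CellTiter-Glo and resazurin assay, with a stated time of 72 h (a higher number here means that more compound is needed for the effect, a lower number that less compound is needed), compound 1 gives only a limit, > 26000 nM. In this assay compound 2 likewise gives only a limit, > 22300 nM. For the measured compounds named here, the single measured step, a step that the two limits leave unreadable from compound 1 to compound 2, has no readable size, since both of its ends are limits (the limit of > 26000 nM in this assay, at which 1 of the 2 values shown sits, (the limit of > 22300 nM in this assay, at which 1 of the 2 values shown sits)). Compound 2 therefore stands at a limit in this assay, with no number of its own among the two values shown. Compound 3 `CCOC(=O)CCCCCOc1cccc(CN(C(=O)c2ccc(-c3cc(OC)cc(OC)c3)cc2)C(C)C)c1` differs from compound 2 by 3,5-dimethoxyphenyl in place of 3-ethoxyphenyl on an aromatic carbon. No measured step bears directly on this change, and the one step shown offers no size to lean on. Against that background, compound 3 is expected to give no step beyond the scatter, a step that the limit leaves unreadable from compound 2 to compound 3. Compound 3 is thus estimated at 30000 nM in this assay, with a range from 12000 nM to 75000 nM, and most probably reported again only as a limit.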

Compound 3, half-maximal effective concentration: > 26000 nM
Compound 3 gave a limit, no number (the forecaster's own chance of this, stated with the estimate: 80%); the middle value lies beyond the limit too.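

In this assay compound 3 gives only a limit, > 26000 nM. The steps among compound 1, compound 2 and compound 3 all join limits and cannot be read. The compounds shown leave open whether pyridin-3-yl, 3-ethoxyphenyl and 3,5-dimethoxyphenyl differ at all in this assay.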